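Enantiomer swap at the benzylic thioether of compound 3

This account rests on a few compounds, and the source may have more. Where it says the series, first, only, none or still open, it means among the compounds named here.

Among the three compounds measured in an assay on isolated protein for inhibition of retinal dehydrogenase 2 (Homo sapiens) (a higher number here means a weaker inhibitor, a lower number a stronger inhibitor), compound 3 `C[C@@H](Sc1nc2c(cnn2C)c(=O)n1-c1ccccc1)c1ccccc1` gives 40 nM, the lowest number of the set. Compound 1 `CC(Sc1nc2c(cnn2C)c(=O)n1-c1ccc(CCO)cc1)c1ccccc1` gives 216 nM in this assay, and compound 2 `Cn1ncc2c(=O)n(-c3ccccc3)c(SCc3cccc(F)c3)cc21` gives 240 nM, both beyond the scatter above compound 3. Neither pair forms a single-point step from compound 3, since compound 1 carries a different substituent on its aryl ring and compound 2 has a different core and side chain, so these numbers serve only as context.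

Compound 4 `C[C@H](Sc1nc2c(cnn2C)c(=O)n1-c1ccccc1)c1ccccc1` differs from compound 3 in this way: the two compounds have the same atoms and bonds and differ only in configuration as drawn: 1 of 1 stereo elements differ; a stereocentre at a saturated chain carbon is drawn R in compound 3 and S in compound 4. Among the compounds with values here, no measured pair in this set shows what such a change does in this assay. A mirror-image change at a stereocentre adjacent to the thioether commonly separates the two forms by a step beyond the scatter, and compound 3 already sits at the strong end of the set, so compound 4 is expected to give the weaker number. The estimated step of a 6.3-fold higher number from compound 3 to compound 4 (0.80 log units; beyond the scatter) reflects this expectation. Compound 4 is thus estimated at 250 nM, with a range from 60 nM to 1500 nM.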

Compound 4, half-maximal inhibitory concentration: 1480 nM
Beside the measured number, compound 4's estimate is 5.9-fold (0.77 log units) below it; measured number inside the range.
By their numbers in this assay, from the lowest: compound 3; then compounds 1 and 2 (each within the scatter of the next); then compound 4.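

In this assay, the configuration at this saturated chain carbon matters on its own, with a 37-fold higher number from compound 3 to compound 4 (1.57 log units; beyond the scatter). The earlier compounds shown here could not show this, since none of them formed a single-point pair with compound 3, compound 1 is drawn without a configuration at this carbon, and compound 2 has no stereocentre there. The whole step can be assigned to the stereocentre, drawn R in compound 3 and S in compound 4, because nothing else separates the two structures: the fact that compounds 3 and 4 differ only in the configuration as drawn

The compounds shown leave open whether the R form stays the stronger when the methyl group on this carbon gives way to a longer chain such as ethyl. They also leave open how either configuration would fare with a carboxylic acid or an amine on the phenyl ring of the benzylic thioether.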